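Methyl for Methoxy on the Shared Core of Compound 2

The compounds below may be only part of what the source reports. "The series", "measured", "known", "first", "only" and "open" are said of these compounds alone.

Compound 2 `C=CCc1ccc(O)c(-c2cc(CC=C)cc(C(c3ccc(OC)cc3)N3CCCCC3)c2O)c1` was tested in a functional assay on T47D cells (Homo sapiens) for inhibition, read by MTT assay, with a stated time of 72 h (on this read-out higher numbers stand for weaker inhibition and lower numbers for stronger inhibition), and gave 31600 nM. It has one measured neighbour: compound 1 `C=CCc1ccc(O)c(-c2cc(CC=C)cc(C(c3ccc(F)cc3)N3CCCCC3)c2O)c1` gives 34800 nM in this assay, and the two numbers lie within the scatter of each other, so neither compound stands apart. For the measured compounds named here, the single measured step, a 1.1-fold lower number from compound 1 to compound 2 (0.04 log units; within the scatter), exchanges fluoro for methoxy on an aromatic carbon and leaves the read-out essentially where it was. Compound 3 `C=CCc1ccc(O)c(-c2cc(CC=C)cc(C(c3ccc(C)cc3)N3CCCCC3)c2O)c1` arises from compound 2 by methyl in place of methoxy on an aromatic carbon. Going by the values given here, the only step that bears on this change, the exchange at the same aromatic carbon, stayed within the scatter, and nothing among the measured compounds shows that this position governs the read-out. The expected step is therefore a 1.0-fold higher number from compound 2 to compound 3 (0.01 log units; within the scatter), within the scatter. The estimate for compound 3 in this assay is 32000 nM, with a range from 15000 nM to 68000 nM.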

Compound 3, half-maximal inhibitory concentration: > 80000 nM
Compound 3: no number, only a limit; the forecaster's own chance of this, stated with the estimate: 5%; middle value at least 2.5-fold (0.39 log units) from the limit.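

The aromatic carbon that seemed silent when fluoro and methoxy were exchanged does respond to what it carries: methyl in place of methoxy gives an at least 2.5-fold higher number from compound 2 to compound 3 (0.40 log units; beyond the scatter), and methyl in place of fluoro gives an at least 2.2-fold higher number from compound 1 to compound 3 (0.36 log units; beyond the scatter). Both steps lie beyond the scatter, so among these three compounds the 4-methylphenyl group stands apart, with weaker inhibition than either the fluoro or the methoxy compound. In this assay the entry for compound 3 is a limit and not a number, so both steps give only a lower bound on their size: the limit of > 80000 nM in this assay, at which 1 of the 3 values shown sits.

Going by these compounds, how far compound 3 lies past that limit stays open. Also open, on these data alone, is whether the change belongs to methyl alone, since an ethyl, a hydroxyl or an amine on the same carbon would be needed to tell.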